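Acetamide to aryl urea on the shared core

The source may report more compounds than this note shows. Statements on the series, on what has been measured and on what is new or still open speak of the compounds shown alone.

Measured so far:
compound 1, `CC(=O)N(C)c1ccc2[nH]c(-c3n[nH]c4ccccc34)cc2n1`: 5110 nM
compound 2, `CN(c1ccc2[nH]c(-c3n[nH]c4ccccc34)cc2n1)S(=O)(=O)c1ccc(OC(F)(F)F)cc1`: 1170 nM

In a functional assay on HL-60 cells (Homo sapiens) for antiproliferative activity, read by MTT assay, with a stated time of 72 h (on this read-out higher numbers stand for weaker inhibition and lower numbers for stronger inhibition), compound 1 gives 5110 nM, the highest of the two numbers. Compound 2 in this assay gives 1170 nM, a lower number, and the gap lies beyond the scatter. The two compounds share the core of compound 1 and differ in more than one place, so no single step can be read from them.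

Compound 3, `COc1ccc(NC(=O)N(C)c2ccc3[nH]c(-c4n[nH]c5ccccc45)cc3n2)cc1`, has not yet been measured in this assay. It differs from compound 1 in one place: (4-methoxyphenyl)amino in place of methyl on a carbonyl carbon. Going by the values given here, no measured pair shows this exact change.

The only hint of direction comes from compound 2, which carries a larger group than compound 1 and gives a lower number in this assay, because compound 2 gives 1170 nM, a gap beyond the scatter from compound 1. On that basis a modest step downward is expected from compound 1 to compound 3, a 2.6-fold lower number from compound 1 to compound 3 (0.41 log units; beyond the scatter), with a wide range. For compound 3 in this assay the estimate is 2000 nM, with a range from 600 nM to 6500 nM.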

Compound 3, half-maximal inhibitory concentration: 7.9 nM
For compound 3 the middle estimate is 250-fold (2.40 log units) above the measured one; the whole stated range lies above it.
By their numbers in this assay, from the lowest: compound 3; then compound 2; then compound 1.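

In this assay the replacement of methyl by (4-methoxyphenyl)amino on a carbonyl carbon gives a 650-fold lower number from compound 1 to compound 3 (2.81 log units; beyond the scatter) and so shows that this position responds strongly to the group placed there, which compound 1 and compound 2 could not show as a single step. The change turns the acetamide of compound 1 into the aryl urea of compound 3, and it brings in a six-membered aromatic ring of carbon only, a hydrogen-bond donor and a hydrogen-bond acceptor all at once. This single step cannot divide the gain among those features. No measurement at hand accounts for the size of the step.

A plain phenylamino group on the same carbonyl carbon would test whether the methoxy group contributes to the step, and a dimethylamino group would test whether the aromatic ring is needed. A benzyl group there remains a further open case, since it would keep an aromatic ring while replacing the nitrogen of the (4-methoxyphenyl)amino group with carbon.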